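Swapping 4-bromophenyl for tert-butyl in an antiproliferative series

This account rests on a few compounds, and the source may have more. Where it says the series, first, only, none or still open, it means among the compounds named here.

For the measured compounds named here, in a functional assay on HCT-116 cells (Homo sapiens) for antiproliferative activity, read by MTT assay, with a stated time of 72 h (a higher number here means a weaker inhibitor, a lower number a stronger inhibitor), compound 1 `O=C1O[C@H]([C@@H](O)Cn2cc(-c3ccc(Br)cc3)nn2)C(OCc2ccccc2)=C1OCc1ccccc1` gives 9420 nM, the only actual number so far. Compound 2 `O=C1O/C(=C\Cn2cc(-c3cc(C(F)(F)F)cc(C(F)(F)F)c3)nn2)C(OCc2ccccc2)=C1OCc1ccccc1` gives only a limit of the assay, > 100000 nM. Compound 3 `CC(C)(C)c1cn(C[C@H](O)[C@H]2OC(=O)C(OCc3ccccc3)=C2OCc2ccccc2)nn1` carries tert-butyl in place of 4-bromophenyl on an aromatic carbon, and so gives up that group's six-membered aromatic ring: tert-butyl in place of 4-bromophenyl on an aromatic carbon. Going by the values given here, no measured step bears on this change, so only a moderate weakening in this assay is expected, an estimated 2.7-fold higher number from compound 1 to compound 3 (0.42 log units; beyond the scatter). For compound 3 the estimated value is 25000 nM, with an expected range from 8000 nM to 90000 nM.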

Compound 3, half-maximal inhibitory concentration: 28300 nM
Beside the measured number, compound 3's estimate is 1.1-fold (0.05 log units) below it; the measured number falls inside the stated range.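

In this assay, for the compounds shown here, tert-butyl in place of 4-bromophenyl gives a 3.0-fold higher number from compound 1 to compound 3 (0.48 log units; beyond the scatter) as the first measured step at this position. A group with no ring therefore still gives a measured value here, so the six-membered aromatic ring of 4-bromophenyl is not essential for activity in this assay, although the step is beyond the scatter. Nothing in the data shown accounts for the size of this step. The compounds shown leave open whether plain phenyl or cyclohexyl would read closer to compound 1 or to compound 3, so the contributions of the bromine and the ring remain unseparated.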